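The source may hold more compounds than are shown below. What is called first, only, known or untested is meant among the compounds shown, and "the series" means these compounds.

Measured compounds:
compound 1, `CC(Br)C(=O)Nc1ccc(Cl)c(C(=O)NC(N)=O)c1`, 2550 nM
compound 2, `COC(=O)c1cc(NC(=O)C(C)Br)cc(C(=O)NC(N)=O)c1`, 2700 nM
compound 3, `NC(=O)NC(=O)c1cc(NC(=O)CBr)ccc1Cl`, 540 nM

All three were tested in a functional assay on CCRF-CEM cells (Homo sapiens) for antiproliferative activity, read by trypan blue exclusion, with a stated time of 72 h; on this read-out lower numbers stand for stronger inhibition and higher numbers for weaker inhibition. Compound 1 and compound 3 share a core and differ only by hydrogen in place of methyl on a saturated chain carbon bound to a bromine atom and a carbonyl carbon; that change gave a 4.7-fold lower number from compound 1 to compound 3 (0.67 log units; beyond the scatter). Compound 2 carries a different core; the difference between the core of compound 2 and the core of compound 1 is not broken down here. In this assay compound 2 and compound 1 give values within the scatter of each other, so no order between them is claimed.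

Compound 4, `COC(=O)c1cc(NC(=O)CBr)cc(C(=O)NC(N)=O)c1`, has not yet been measured. It differs from compound 2 by hydrogen in place of methyl on a saturated chain carbon bound to a bromine atom and a carbonyl carbon, which is the same change as that from compound 1 to compound 3, on the same place. Among the compounds with values here, only one measured instance of the change exists, so the expectation rests on a single step. Because the step of a 4.7-fold lower number from compound 1 to compound 3 (0.67 log units; beyond the scatter) was modest and beyond the scatter, a step of similar size is expected from compound 2 to compound 4, namely a 4.5-fold lower number from compound 2 to compound 4 (0.65 log units; beyond the scatter). Compound 4 is therefore estimated at 600 nM, with a range from 300 nM to 1300 nM.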

Compound 4, half-maximal inhibitory concentration: 1300 nM
Compound 4: the middle estimate sits 2.2-fold (0.34 log units) below what was measured; the measured number falls inside the stated range.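

Replacing 1-bromoethyl by bromomethyl gives a 2.1-fold lower number from compound 2 to compound 4 (0.32 log units; beyond the scatter) in this assay and so runs the same way as it did on the core of compound 1. This shows that the direction of the change carried over between these two cores, but two pairs do not fix a size for the step or show that it would hold on any further core. The two sizes themselves cannot be told apart, so a single shared step size remains compatible with the data, without being established by them: the same change on two cores in this assay, a 4.7-fold lower number (0.67 log units; beyond the scatter) from compound 1 to compound 3 and a 2.1-fold lower number (0.32 log units; beyond the scatter) from compound 2 to compound 4, 2.3-fold (0.36 log units) apart, within the scatter of two such steps

The compounds shown leave open how a chloromethyl group in place of bromomethyl, or a longer chain carrying the bromine atom, would read in this assay on either core. Also open, from the compounds shown here alone, is whether the same change would keep its direction on a core carrying a carboxylic acid or an amine in place of the chlorine atom or the methyl ester.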